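Swapping a hydroxylated side group for a pyridine ring

The source may hold more compounds than are shown below. What is called first, only, known or untested is meant among the compounds shown, and "the series" means these compounds.

Measured in a physicochemical assay for lipophilicity, read by HPLC, measured as chromatographic lipophilicity, at pH 7.4; a lower number here means a more polar compound, a higher number a more lipophilic compound:
- compound 1 `Cc1nnc(N2CCC(C(=O)N3N=CC[C@H]3c3ccccc3)CC2)o1`: 3.2
- compound 2 `O=C(C1CCC1)N1N=CCC1c1ccccc1`: 4.7
- compound 3 `CC(C)(CO)C(=O)N1N=CCC1c1ccccc1`: 3.4

All three compounds are amides built on a shared core, and they differ in what is attached to the carbonyl carbon of that core or, for compound 1, in a larger group there. In this assay compound 3 reads 3.4. That cannot be told apart from compound 1 within the usual scatter, while compound 2 stands clearly higher.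

Compound 4 `O=C(c1ccncc1)N1N=CCC1c1ccccc1` is the next case. It carries pyridin-4-yl in place of 1-(hydroxymethyl)-1-methylethyl on a carbonyl carbon.

Among the measured compounds shown here, only one measured step bears on this change, as it sits at the same place: a number 1.30 log units lower from compound 2 to compound 3 (beyond the scatter). That step is large, and it ends at the same group that compound 4 gives up. Compound 4 resembles compound 2 in having a ring at this place and no hydroxymethyl, but its ring contains a hetero atom. For the measured compounds named here, no measured compound carries pyridin-4-yl, so it should recover only part of that step. A modest upward move is therefore expected, estimated as a number 0.40 log units higher from compound 3 to compound 4 (beyond the scatter). For compound 4 the estimate is 3.8, with an expected range from 3.2 to 4.4.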

Compound 4, distribution coefficient: 2.7
Compound 4: the middle estimate sits 1.10 log units above what was measured; the whole stated range lies above it.
By their numbers in this assay, from the lowest: compound 4; then compounds 1 and 3 (each within the scatter of the next); then compound 2.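

At this place, on a carbonyl carbon attached to an amide-type nitrogen in a ring, pyridin-4-yl in place of 1-(hydroxymethyl)-1-methylethyl gives a number 0.70 log units lower from compound 3 to compound 4 (beyond the scatter) in this assay, so a group with no hydrogen-bond donor can read lower here than one that has a donor. A ring at this place does not by itself keep the number high either: pyridin-4-yl in place of cyclobutyl gives a number 2.00 log units lower from compound 2 to compound 4 (beyond the scatter) in this assay, a larger move than a number 1.30 log units lower from compound 2 to compound 3 (beyond the scatter) seen when the hydroxylated group replaced cyclobutyl. No independent measurement is available to explain why these two rings read so differently.

The compounds shown do not separate the contribution of the ring nitrogen from that of the aromatic ring, and a plain phenyl group at this place would make that comparison directly. Pyridin-3-yl, with the same atoms as pyridin-4-yl but a different attachment point, would show whether the reading depends only on the atoms present or also on how the ring is connected to the carbonyl carbon.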